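The source may report more compounds than this note shows. Statements on the series, on what has been measured and on what is new or still open speak of the compounds shown alone.

Within the data shown here, in an ADME assay on HepG2 cells (Homo sapiens) for cytotoxicity, read by MTT assay, with a stated time of 24 h (on this read-out higher numbers stand for lower toxicity in this test and lower numbers for higher toxicity in this test), compound 1 `CC(C)=CCC1=C(OCc2cn(Cc3ccccc3)nn2)C(=O)c2ccccc2C1=O` gives 414000 nM, the lowest of the three numbers so far. Compound 2 `CC(C)=CCC1=C(OCc2cn(Cc3ccccn3)nn2)C(=O)c2ccccc2C1=O` gives 658000 nM, and compound 3 `CC(C)=CCC1=C(OCc2cn(-c3cccnc3)nn2)C(=O)c2ccccc2C1=O` gives 1030000 nM. The step of a 1.6-fold higher number from compound 1 to compound 2 (0.20 log units; within the scatter) stays within the scatter, and so does a 1.6-fold higher number from compound 2 to compound 3 (0.19 log units; within the scatter), while a 2.5-fold higher number from compound 1 to compound 3 (0.40 log units; beyond the scatter) is modest but beyond it. Compound 4 `COc1ccc(-n2cc(COC3=C(CC=C(C)C)C(=O)c4ccccc4C3=O)nn2)cc1` differs from compound 1 in one place: 4-methoxyphenyl in place of benzyl on an aromatic nitrogen. Like compound 3, compound 4 bears its new group on the aromatic nitrogen rather than on a saturated chain carbon, so the step from compound 1 to compound 3 bears most on it, and a rise of similar modest size, or none beyond the scatter, is expected. Compound 4 is estimated at 700000 nM, within 350000 nM to 1400000 nM, an expected 1.7-fold higher number from compound 1 to compound 4 (0.23 log units; within the scatter).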

Compound 4, half-maximal cytotoxic concentration: 200000 nM
Estimate against measurement, compound 4: 3.5-fold (0.54 log units) above, and the stated range ends above it.
By their numbers in this assay, from the lowest: compound 4; then compounds 1, 2 and 3 (each within the scatter of the next, the first and the last beyond it).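

What sits on the aromatic nitrogen can move the number in either direction in this assay: 4-methoxyphenyl in place of benzyl lowers it (a 2.1-fold lower number from compound 1 to compound 4 (0.32 log units; beyond the scatter)), and the gaps to the pyridine-bearing compounds are wider (a 5.2-fold lower number from compound 3 to compound 4 (0.71 log units; beyond the scatter); a 3.3-fold lower number from compound 2 to compound 4 (0.52 log units; beyond the scatter)). Compound 3 and compound 4 both lack the saturated chain carbon of benzyl, so losing that carbon does not alone set the direction. No measurement here explains the drop. As far as these compounds go, whether the methoxy group itself goes with the lower number stays open; a plain phenyl or 4-aminophenyl group on that nitrogen would bear on this.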